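Ring enlargement at the amine of compound 2

A few compounds are considered here, and "the series" means these few. Any claim that something is new, unique, unknown or untested is made for them only; others in the source may bear on it.

For the measured compounds named here, compound 2 `CC1CCCN1c1ccc2cc(NC(=O)CCc3ccc(C(F)(F)F)cc3)ccc2n1` is one of two compounds measured so far in a functional assay on HEK293 cells for activation of melanin-concentrating hormone receptor 1 (Rattus norvegicus), read by inositol phosphate accumulation; a higher number here means that more compound is needed for the effect, a lower number that less compound is needed. Compound 2 gives 270 nM, the highest of the two numbers, while compound 1 `CC(C)N(C)c1ccc2cc(NC(=O)CCc3ccc(C(F)(F)F)cc3)ccc2n1` gives 140 nM; the step of a 1.9-fold higher number from compound 1 to compound 2 (0.29 log units; within the scatter) lies within the scatter, so no order between the two compounds can be claimed.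

The next compound, compound 3 `O=C(CCc1ccc(C(F)(F)F)cc1)Nc1ccc2nc(N3CCCCCC3)ccc2c1`, has not yet been measured. It differs from compound 2 in one place: azepan-1-yl in place of 2-methylpyrrolidin-1-yl on an aromatic carbon.

Going by the values given here, only one measured step bears on this change, the earlier exchange of one amine group for another on the same aromatic carbon, a 1.9-fold higher number from compound 1 to compound 2 (0.29 log units; within the scatter). That step stayed within the scatter. Replacing the five-membered ring of compound 2 with a seven-membered ring is a somewhat larger alteration, but the numbers give no sign that this amine substituent sets the result strongly. A step of a 1.1-fold higher number from compound 2 to compound 3 (0.05 log units; within the scatter) is therefore expected, staying within the scatter. Compound 3 is estimated at 300 nM, with a range from 110 nM to 850 nM.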

Compound 3, half-maximal effective concentration: 1800 nM
For compound 3 the middle estimate is 6.0-fold (0.78 log units) below the measured one, and the stated range ends below it.
By their numbers in this assay, from the lowest: compounds 1 and 2 (each within the scatter of the next); then compound 3.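

In this assay, for the compounds shown here, azepan-1-yl gives the first step at this position that lies beyond the scatter, a 6.7-fold higher number from compound 2 to compound 3 (0.82 log units; beyond the scatter), and the comparison with the open-chain amine gives a larger one, a 13-fold higher number from compound 1 to compound 3 (1.11 log units; beyond the scatter). This aromatic carbon next to the ring nitrogen therefore does not accept every amine alike: isopropyl(methyl)amino and 2-methylpyrrolidin-1-yl cannot be told apart, whereas the seven-membered ring stands clearly apart from both, needing more compound for the effect. No available evidence accounts for this difference.

The change from compound 2 to compound 3 enlarges the ring and also removes the methyl group, so the compounds shown cannot separate these two alterations. Pyrrolidin-1-yl, without the methyl group, and piperidin-1-yl, with its six-membered ring, would be needed to show which alteration carries the step and whether the number climbs gradually with ring size or only once the ring reaches seven members.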